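The compounds below may be only part of what the source reports. "The series", "measured", "known", "first", "only" and "open" are said of these compounds alone.

Compound 1 `COc1ccc(/C=C/C(=O)/C(C)=C/c2ccc(OC)cc2)cc1`: 75000 nM
Compound 2 `COc1ccc(/C=C(\C)C(=O)/C=C/c2ccc([N+](=O)[O-])cc2)cc1`: 20100 nM
Compound 3 `COc1ccc(/C=C(\C)C(=O)/C=C/c2ccc(N(C)C)cc2)cc1`: 411000 nM

In an ADME assay on LLC-MK2 cells (Macaca mulatta) for cytotoxicity, read by MTT assay, with a stated time of 48 h (on this read-out higher numbers stand for lower toxicity in this test and lower numbers for higher toxicity in this test), compound 1 stands second highest of the three, with compound 2 lower and compound 3 higher. Compound 4 `COc1ccc(/C=C/C(=O)/C(C)=C/c2ccc([N+](=O)[O-])cc2)cc1` is compound 1 with nitro in place of methoxy on an aromatic carbon. Within the data shown here, the closest precedent is a 3.7-fold lower number from compound 1 to compound 2 (0.57 log units; beyond the scatter), the same exchange made at the other methoxy group. a 5.5-fold higher number from compound 1 to compound 3 (0.74 log units; beyond the scatter) brings in dimethylamino instead, so it bears only indirectly, as does a 20-fold higher number from compound 2 to compound 3 (1.31 log units; beyond the scatter). A modest step to a lower number, meaning higher toxicity, is therefore expected in this assay. The expected step is a 3.1-fold lower number from compound 1 to compound 4 (0.49 log units; beyond the scatter). The estimated value for compound 4 is 24000 nM, with an expected range of 9000 nM to 65000 nM.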

Compound 4, half-maximal cytotoxic concentration: 172000 nM
The estimate for compound 4 lay 7.2-fold (0.86 log units) below the measured number; measured number outside the range, above it.
By their numbers in this assay, from the lowest: compound 2; then compound 1; then compound 4; then compound 3.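

In this assay, nitro in place of methoxy at this position gives a 2.3-fold higher number from compound 1 to compound 4 (0.36 log units; beyond the scatter), whereas the same exchange at the other methoxy group gives a 3.7-fold lower number from compound 1 to compound 2 (0.57 log units; beyond the scatter). The direction of this exchange therefore differs between the two methoxy groups of compound 1, so the earlier nitro result does not carry over to this position. Nothing given here explains that reversal. Going by these compounds, it remains open whether an amine or a carboxylic acid at this position would raise or lower the number, and whether either would behave the same way at the other methoxy group.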